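The source may report more compounds than this note shows. Statements on the series, on what has been measured and on what is new or still open speak of the compounds shown alone.

In an ADME assay on MRC5 cells (Homo sapiens), read by MTT assay, with a stated time of 72 h (a higher number here means a weaker inhibitor, a lower number a stronger inhibitor), compound 1, `CSc1ncnc2c1c(-c1cccs1)cn2[C@@H]1O[C@H](CO)[C@@H](O)[C@H]1O`, gives > 100000 nM, which is a limit and not a number. Compound 2, `CNc1ncnc2c1c(-c1cccs1)cn2[C@@H]1O[C@H](CO)[C@@H](O)[C@H]1O`, gives > 100000 nM, again a limit and not a number. Compound 2 therefore stands with compound 1 at the limit of > 100000 nM in this assay, at which 2 of the 2 values shown sit, and neither compound has a readable value. Going by the values given here, the one measured step, methylamino in place of methylsulfanyl on an aromatic carbon, is a step that the two limits leave unreadable from compound 1 to compound 2. It offers no size to carry forward, and it concerns a different place on the shared core.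

Compound 3, `C#Cc1cn([C@@H]2O[C@H](CO)[C@@H](O)[C@H]2O)c2ncnc(NC)c12`, has ethynyl in place of thiophen-2-yl on an aromatic carbon, with the methylamino group kept: ethynyl in place of thiophen-2-yl on an aromatic carbon. Among the compounds with values here, no measured step covers this exchange, so any forecast is loose. The expected direction rests on compound 2, whose > 100000 nM is a limit: a readable number for compound 3 in this assay would have to be lower, meaning a stronger inhibitor. The expected change is an at least 2.5-fold lower number from compound 2 to compound 3 (0.39 log units; beyond the scatter), and compound 3 may well stay at the limit. For compound 3 the estimate is 40000 nM, with an expected range from 2000 nM to 100000 nM.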

Compound 3, half-maximal inhibitory concentration: > 100000 nM
Compound 3 ended at the assay's limit; the forecaster's own chance of this, stated with the estimate: 50%; middle value at least 2.5-fold (0.39 log units) away from the limit.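

The step from compound 2 to compound 3, ethynyl in place of thiophen-2-yl, cannot be read, and all three compounds rest at one limit rather than a number: the limit of > 100000 nM in this assay, at which 3 of the 3 values shown sit.

The compounds shown leave open whether either exchange changes the number in this assay at all, and by how much.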